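The source may hold more compounds than are shown below. What is called first, only, known or untested is meant among the compounds shown, and "the series" means these compounds.

Series notes on the step from compound 3 to compound 4. In a functional assay on the whole organism for inhibition, with Rattus norvegicus as the target (a higher number here means that more compound is needed for the effect, a lower number that less compound is needed), compound 3 `CCCSc1nsnc1[C@H]1CN2CCC[C@@H]1C2` gives 0.013 mg/kg, the lowest of the two numbers shown. Compound 1 `CCCCSc1nsnc1[C@H]1CN2CCC[C@@H]1C2` gives 0.017 mg/kg in this assay, and the step of a 1.3-fold lower number from compound 1 to compound 3 (0.12 log units; within the scatter) is within the scatter, so the two compounds stand level on this read-out. Among the compounds with values here, compound 2 `CCCCSc1nsnc1C1CN2CC[C@@H]1C2` reaches only a limit in this assay, > 1 mg/kg, a bound of the assay rather than a number; it differs from compound 3 in both its core and its chain length, so no single step is counted for it. the limit of > 1 mg/kg in this assay, at which 1 of the 3 values shown sits, describes where that one value sits. Within the data shown here, compound 4 `CCCSc1nsnc1[C@@H]1CN2CCC[C@@H]1C2` is the next entry, not yet measured in this assay. the two compounds have the same atoms and bonds; at least one stereo element is drawn with a configuration in one of them and without one in the other: 1 of 3 stereo elements differ; a stereocentre at a saturated ring carbon is drawn R in compound 3 and S in compound 4 Neither measured comparison touches a stereocentre: the one counted step, a 1.3-fold lower number from compound 1 to compound 3 (0.12 log units; within the scatter), shortens the chain and stays within the scatter, and the pair compound 2 and compound 3 is not a single step. There is nothing in the series to size a stereo inversion from, so the expectation for compound 4 is a higher number than compound 3 with a wide range, a 6.2-fold higher number from compound 3 to compound 4 (0.79 log units; beyond the scatter), giving an estimate of 0.08 mg/kg between 0.013 mg/kg and 1 mg/kg.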

Compound 4, dose for half-maximal effect: > 3 mg/kg
Compound 4: only a limit was reported; the forecaster's own chance of this, stated with the estimate: 25%; middle value at least 37-fold (1.57 log units) away from the limit.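

In this assay the result is an at least 230-fold higher number from compound 3 to compound 4 (2.36 log units; beyond the scatter), a large change made with no atom or bond entering or leaving. Compound 4 reaches only a limit, > 3 mg/kg, which is a bound of the assay and not a number. Unlike the chain step, a 1.3-fold lower number from compound 1 to compound 3 (0.12 log units; within the scatter), which stays within the scatter, this change shows that the series is highly sensitive to the configuration at one saturated ring carbon, drawn R in compound 3 and S in compound 4, and the structural record for the pair is this: the fact that one of compounds 3 and 4 is drawn with a defined configuration and the other without, at the place where they differ

Going by these compounds, the true size of the step stays open, since one end of it is a limit, and so does whether the S configuration at this carbon carries the same penalty with the longer chain of compound 1. Also open, on these data alone, is whether a still longer chain, or an oxygen in place of the sulfur, would hold the level shared by compound 1 and compound 3 on the R-drawn core, and how the other stereocentres of the core contribute.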